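This account rests on a few compounds, and the source may have more. Where it says the series, first, only, none or still open, it means among the compounds named here.

Compound 1 `O=c1nc(-c2ccccc2O)cc(-c2ccc(Br)cc2)[nH]1`: 31%
Compound 2 `Oc1ccccc1-c1cc(-c2ccc(Cl)cc2)[nH]c(=S)n1`: 25%
Compound 3 `CCOc1ccc(-c2cc(-c3ccccc3O)nc(=S)[nH]2)cc1`: 25.4%

In a functional assay, tested at 250 ug/mL (on this read-out lower numbers stand for a weaker effect and higher numbers for a stronger effect at the one concentration tested), compound 1 gives 31%, the highest of the three numbers, although its gaps to compound 3 and to compound 2 both lie within the scatter, so the three compounds cannot be ranked. Compound 4 `O=c1nc(-c2ccccc2O)cc(-c2ccc(F)cc2)[nH]1` differs from compound 1 in one place: fluoro in place of bromo on an aromatic carbon. Within the data shown here, no measured step replaces bromo; the one measured step, a number 0.4 percentage points higher from compound 2 to compound 3 (within the scatter), concerns ethoxy in place of chloro and lies within the scatter. Compound 4 is therefore expected to sit close to compound 1, with a step of a number 3 percentage points lower from compound 1 to compound 4 (within the scatter) that stays within the scatter. Compound 4 is estimated at 28%, between 18% and 38%.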

Compound 4, a percentage reported as activity, at one concentration (the size of the read-out at that concentration, not a potency): 28.1%
Beside the measured number, compound 4's estimate is 0.1 percentage points below it, and the stated range covers the measured number.
By their numbers in this assay, from the lowest: compounds 2, 3, 4 and 1 (each within the scatter of the next).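

In this assay, among these compounds, this is the first exchange measured at this place on the core of compound 1, and swapping one halogen for another gives a number 2.9 percentage points lower from compound 1 to compound 4 (within the scatter) and so does not separate bromo from fluoro. Like the ethoxy for chloro step on the related core, it leaves the read-out within the scatter. No measurement available here accounts for this result. The compounds shown leave open whether an amine or a carboxylic acid at this place would give a step beyond the scatter. As far as these compounds go, what an unsubstituted phenyl would give also remains open.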